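The compounds below may be only part of what the source reports. "The series", "measured", "known", "first", "only" and "open" are said of these compounds alone.

Measured so far in a functional assay on DU-145 cells (Homo sapiens) for cytotoxicity, read by MTT assay, with a stated time of 48 h; on this read-out lower numbers stand for stronger inhibition and higher numbers for weaker inhibition:
- compound 1, `Cc1ccc(S(=O)(=O)/N=C(/CCNC2=CC(=O)c3ccccc3C2=O)Nc2ccc(F)cc2)cc1`, with compound 1 giving 12200 nM
- compound 2, `Cc1ccc(S(=O)(=O)/N=C(/CCNC2=CC(=O)c3ccccc3C2=O)Nc2cccc(C)c2)cc1`, with compound 2 giving 10200 nM
- compound 3, `COc1ccc(N/C(CCNC2=CC(=O)c3ccccc3C2=O)=N\S(=O)(=O)c2ccc(C)cc2)cc1OC`, with compound 3 giving 17800 nM

All three share one core and differ only in the group on an amine nitrogen. Compound 3 carries the highest number of the three, yet the gaps separating it from the others, a 1.5-fold higher number from compound 1 to compound 3 (0.16 log units; within the scatter) and a 1.7-fold higher number from compound 2 to compound 3 (0.24 log units; within the scatter), both lie within the scatter, as does a 1.2-fold lower number from compound 1 to compound 2 (0.08 log units; within the scatter). So far, then, swapping one substituted phenyl group for another on this nitrogen has left this assay essentially unmoved.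

Compound 4, `Cc1ccc(S(=O)(=O)/N=C(/CCNC2=CC(=O)c3ccccc3C2=O)Nc2ccc(Cl)cc2Cl)cc1`, continues this series: 2,4-dichlorophenyl in place of 3,4-dimethoxyphenyl on an amine nitrogen. Going by the values given here, none of the measured steps involves a 2,4-dichlorophenyl, so no step bears on it directly; the nearest guide is that every phenyl swap seen so far, including the one to the halogen-bearing 4-fluorophenyl of compound 1 at 12200 nM, stayed within the scatter. A step of no more than the scatter is therefore expected, with a 1.4-fold lower number from compound 3 to compound 4 (0.14 log units; within the scatter) the estimated outcome. Compound 4 is expected to give about 13000 nM, most likely between 6000 nM and 30000 nM.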

Compound 4, half-maximal inhibitory concentration: 18600 nM
Compound 4: the middle estimate sits 1.4-fold (0.16 log units) below what was measured; the range from low to high includes it.
By their numbers in this assay, from the lowest: compounds 2, 1, 3 and 4 (each within the scatter of the next).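

In this assay, the 2,4-dichlorophenyl group on the amine nitrogen fits with the three phenyl groups seen earlier, giving a 1.0-fold higher number from compound 3 to compound 4 (0.02 log units; within the scatter), a 1.8-fold higher number from compound 2 to compound 4 (0.26 log units; within the scatter) and a 1.5-fold higher number from compound 1 to compound 4 (0.18 log units; within the scatter). The flat picture at this position therefore now extends to a group with two chlorine atoms and 0 hydrogen-bond acceptors, and exchanging it for the 3,4-dimethoxyphenyl group, with 2 hydrogen-bond acceptors, leaves the number within the scatter. Nothing available explains why this position tolerates such different groups.

On these data alone, all four compounds keep a substituted phenyl group on this nitrogen, so it remains open whether a plain ethyl chain, or a phenyl group carrying a carboxylic acid, would shift the number. The compounds shown also cannot tell whether changes to the shared core would matter more.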